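This account rests on a few compounds, and the source may have more. Where it says the series, first, only, none or still open, it means among the compounds named here.

Measured in a functional assay on the whole organism (strain Kunming) with Mus musculus as the target, with a stated time of 0.5 h; a higher number here means that more compound is needed for the effect, a lower number that less compound is needed:

- compound 1 `COc1cc(OC)c(OC)cc1/C=C/COC(=O)/C=C/c1cc(OC)c(OC)c(OC)c1OC` gives 65.1 umol/kg
- compound 2 `COc1cc(OC)c(OC)cc1/C=C/COC(=O)/C=C/c1ccc(Br)cc1` gives 143 umol/kg
- compound 3 `COc1cc(OC)c(OC)cc1/C=C/COC(=O)/C=C/c1ccc(OC)c(OC)c1OC` gives 75.1 umol/kg

Compound 2 at 143 umol/kg lies beyond the usual scatter from compound 1, needing more compound for the effect, but within the scatter of compound 3. Compound 4 `COc1ccc(/C=C/C(=O)OC/C=C/c2cc(OC)c(OC)cc2OC)cc1` has not yet been measured. It keeps the core of compound 2 and alters one group: methoxy in place of bromo on an aromatic carbon. In short, this is methoxy in place of bromo on an aromatic carbon.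

Within the data shown here, no measured pair makes this exact swap. Among the measured compounds shown here, the one measured step that bears on it does so only indirectly, since hydrogen in place of methoxy on an aromatic carbon gives a 1.2-fold higher number from compound 1 to compound 3 (0.06 log units; within the scatter). Compound 1 and compound 3 both carry methoxy in the place where compound 2 carries bromo, which gives a weak hint towards a lower number. The expected change is small and is estimated as a 1.4-fold lower number from compound 2 to compound 4 (0.16 log units; within the scatter), and it may not clear the scatter. For compound 4 the estimated value is 100 umol/kg, with an expected range from 50 umol/kg to 190 umol/kg in this assay.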

Compound 4, dose for half-maximal effect: 184 umol/kg
Estimate against measurement, compound 4: 1.8-fold (0.26 log units) below; low and high end bracket the measured number.
By their numbers in this assay, from the lowest: compounds 1, 3, 2 and 4 (each within the scatter of the next, the first and the last beyond it).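

Going from 4-bromophenyl to 4-methoxyphenyl in this assay gives a 1.3-fold higher number from compound 2 to compound 4 (0.11 log units; within the scatter) and so offers the first direct reading of this position, on an aromatic carbon para to a large group. Within this pair, a single bromine and a methoxy group can occupy that place without a difference that can be told apart from ordinary measurement noise. Nothing available explains why the two groups read alike.

Among these compounds, one swap cannot show whether this position is indifferent to its substituent in general, since bromo and methoxy are the only two groups compared here on an otherwise identical core. An amine or a carboxylic acid at the same place could test whether the number can move beyond the scatter at all.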